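Lengthening the Carbamate Side Chain of Compound 2

The source may hold more compounds than are shown below. What is called first, only, known or untested is meant among the compounds shown, and "the series" means these compounds.

In a functional assay on MDA-MB-231 cells (Homo sapiens) for inhibition, read by MTT assay, with a stated time of 72 h (on this read-out lower numbers stand for stronger inhibition and higher numbers for weaker inhibition), compound 1 `COC(=O)NCCOc1ccc(Cl)cc1C(=O)N[C@H](C(=O)Nc1ccc([N+](=O)[O-])cc1Cl)C(C)C` reads > 10000 nM, and this is a limit of the assay and not a number. Within the data shown here, compound 2 `CC(C)COC(=O)NCCOc1ccc(Cl)cc1C(=O)N[C@H](C(=O)Nc1ccc([N+](=O)[O-])cc1Cl)C(C)C` gives 4900 nM, the only true number available so far.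

Compound 3 `CC(C)[C@H](NC(=O)c1cc(Cl)ccc1OCCCNC(=O)OC(C)(C)C)C(=O)Nc1ccc([N+](=O)[O-])cc1Cl` carries ((tert-butoxycarbonyl)amino)methyl in place of (isobutoxycarbonyl)amino, and the change amounts to ((tert-butoxycarbonyl)amino)methyl in place of (isobutoxycarbonyl)amino on a saturated chain carbon, two bonds along the chain from an oxygen on an aromatic ring.

Among the measured compounds shown here, one measured step bears on this change: an at least 2.0-fold lower number from compound 1 to compound 2 (0.30 log units; that floor lies within the scatter). It altered the same end of the side chain, but its floor lies within the scatter, so it gives only weak guidance. No step beyond the scatter is therefore expected in this assay.

The estimated change is a 1.2-fold lower number from compound 2 to compound 3 (0.09 log units; within the scatter), which is expected to stay within the scatter. For compound 3 the expected value is 4000 nM, with an estimated range of 1500 nM to 10000 nM.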

Compound 3, half-maximal inhibitory concentration: > 10000 nM
Compound 3: no number, only a limit; the forecaster's own chance of this, stated with the estimate: 20%; middle value at least 2.5-fold (0.39 log units) away from the limit.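

In this assay compound 3 reads > 10000 nM, which is a limit of the assay and not a number. The step, an at least 2.0-fold higher number from compound 2 to compound 3 (0.30 log units; that floor lies within the scatter), shows that moving to the 3-((tert-butoxycarbonyl)amino)propoxy side chain did not bring a gain over the 2-((isobutoxycarbonyl)amino)ethoxy side chain, and compound 2 remains the only one of the three with a true number. The step between compound 1 and compound 3 cannot be read, because both compounds sit at a limit: the limit of > 10000 nM in this assay, at which 2 of the 3 values shown sit.

This change alters the chain and the carbamate end together, so the compounds shown cannot separate the contribution of the extra chain carbon from that of tert-butyl in place of isobutyl. From the compounds shown here alone, it also remains open whether an amine or a carboxylic acid in place of the carbamate would give a true number in this assay.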